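The source may report more compounds than this note shows. Statements on the series, on what has been measured and on what is new or still open speak of the compounds shown alone.

The shared core is a piperazine bearing two trimethoxybenzoyl amides and an ester-linked side chain; compound 1, `CCCC(=O)OCC1CN(C(=O)c2cc(OC)c(OC)c(OC)c2)CCN1C(=O)c1cc(OC)c(OC)c(OC)c1`, carries a butyrate ester and in a functional assay (Oryctolagus cuniculus) for inhibition of platelet-activating factor receptor (Cavia porcellus) (a lower number here means a stronger inhibitor, a higher number a weaker inhibitor), compound 1 gives 420 nM. Compound 2, `CCCCCCCCCC(=O)OCC1CN(C(=O)c2cc(OC)c(OC)c(OC)c2)CCN1C(=O)c1cc(OC)c(OC)c(OC)c1`, carries the longer decanoate chain, and in this assay compound 2 gives 2820 nM, the highest of the two single numbers recorded; its nearest neighbour is compound 1, and the step of a 6.7-fold higher number from compound 1 to compound 2 (0.83 log units; beyond the scatter) lies beyond the scatter. A third member, compound 3, `CCC(CC)C(=O)OCC1CN(C(=O)c2cc(OC)c(OC)c(OC)c2)CCN1C(=O)c1cc(OC)c(OC)c(OC)c1`, with a branched 2-ethylbutanoate ester, has repeated entries and gives 70 nM; 40 nM; 60 nM (3 entries), as recorded in the several entries of compound 3 in this assay, 70 nM; 40 nM; 60 nM (3 entries).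

The untested compound 4, `COc1cc(C(=O)N2CCN(C(=O)c3cc(OC)c(OC)c(OC)c3)C(COC(=O)C3CCCCC3)C2)cc(OC)c1OC`, differs from compound 2 by cyclohexyl in place of nonyl on a carbonyl carbon. Among the measured compounds shown here, since the only measured step, a 6.7-fold higher number from compound 1 to compound 2 (0.83 log units; beyond the scatter), shows that lengthening the ester chain raised the number, removing most of that chain in compound 4 is expected to move it back down, and the values of compound 3 suggest a compact branched acyl group can sit well below compound 1. The estimate for compound 4 is therefore 120 nM, with a range from 35 nM to 450 nM, an expected step of a 24-fold lower number from compound 2 to compound 4 (1.37 log units; beyond the scatter).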

Compound 4, half-maximal inhibitory concentration: 290 nM
Compound 4: middle estimate off by 2.4-fold (0.38 log units), on the low side; measured number inside the range.
By their numbers in this assay, from the lowest: compounds 4 and 1 (each within the scatter of the next); then compound 2.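

Placing cyclohexyl in place of nonyl on the carbonyl carbon in this assay gives a 9.7-fold lower number from compound 2 to compound 4 (0.99 log units; beyond the scatter), so the weak result of compound 2 does not hold for every acyl group larger than propyl at this position. Compound 1 and compound 4 cannot be told apart, even though cyclohexyl holds more carbons than propyl, with a 1.4-fold lower number from compound 1 to compound 4 (0.16 log units; within the scatter) lying within the scatter. Still, a ring does not match the branched open chain, since compound 4 gives 290 nM, a higher number than every entry for compound 3: the several entries of compound 3 in this assay, 70 nM; 40 nM; 60 nM (3 entries)

Nonyl and cyclohexyl differ in both carbon count and ring, so a straight hexyl chain, with the same carbon count as cyclohexyl, would be needed to separate the two. On these data alone, whether cyclopentyl or phenyl on the same carbonyl carbon would behave like cyclohexyl also remains open.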